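Amide-nitrogen aryl swaps on a shared thiazolidinedione core

This account rests on a few compounds, and the source may have more. Where it says the series, first, only, none or still open, it means among the compounds named here.

Measured so far:
compound 1, `Cc1cccc(NC(=O)COc2ccc(/C=C3\SC(=O)NC3=O)cc2)n1`, 75000 nM
compound 2, `O=C(COc1ccc(/C=C2\SC(=O)NC2=O)cc1)Nc1ccc([N+](=O)[O-])cc1`, > 100000 nM
compound 3, `O=C(COc1ccc(/C=C2\SC(=O)NC2=O)cc1)Nc1cccc([N+](=O)[O-])c1`, > 100000 nM

In a functional assay on KB cells (Homo sapiens) for inhibition (a lower number here means a stronger inhibitor of growth, a higher number a weaker inhibitor of growth), compound 1 gives 75000 nM. Compound 2 gives only a limit in this assay, > 100000 nM, and stands at the limit of > 100000 nM in this assay, at which 2 of the 3 values shown sit. Compound 3 likewise gives a limit, > 100000 nM. The step of an at least 1.3-fold higher number from compound 1 to compound 2 (0.12 log units; that floor lies within the scatter) is therefore a floor, and an at least 1.3-fold higher number from compound 1 to compound 3 (0.12 log units; that floor lies within the scatter) is the same kind of floor; the step that the two limits leave unreadable from compound 2 to compound 3 cannot be read.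

Compound 4, `O=C(COc1ccc(/C=C2\SC(=O)NC2=O)cc1)Nc1ccc(F)cc1F`, is not yet measured. Its change from compound 2 is 2,4-difluorophenyl in place of 4-nitrophenyl on an amide-type nitrogen. Among the measured compounds shown here, no measured step exchanges a nitrophenyl for a difluorophenyl, so the only bearing comes from compound 2 sitting at a limit together with compound 3, while compound 1 with its 6-methylpyridin-2-yl sits within scatter of that limit. No step beyond the scatter is expected. For compound 4 the expected value is 90000 nM, with a range from 30000 nM to 300000 nM. This estimate means an expected step of an at least 1.1-fold lower number from compound 2 to compound 4 (0.04 log units; that floor lies within the scatter).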

Compound 4, concentration for 50% growth inhibition: > 100000 nM
Compound 4: no number, only a limit; the forecaster's own chance of this, stated with the estimate: 50%; middle value at least 1.1-fold (0.04 log units) from the limit.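

In this assay compound 4 gives > 100000 nM, which is a limit and not a number. Exchanging 4-nitrophenyl, with 2 hydrogen-bond acceptors, for 2,4-difluorophenyl, with 0, therefore yields no readable value, and a phenyl without a nitro group now shares the limit with the two nitrophenyl compounds: the limit of > 100000 nM in this assay, at which 3 of the 4 values shown sit. The steps to compound 4 from compound 2 and compound 3 cannot be read, while an at least 1.3-fold higher number from compound 1 to compound 4 (0.12 log units; that floor lies within the scatter) is only a floor within the scatter, so the 6-methylpyridin-2-yl group is not separated from the 2,4-difluorophenyl group.

Going by these compounds, whether any group on this amide-type nitrogen gives a clear gain in growth inhibition remains open, as compound 1 alone has a number. An aminophenyl or carboxyphenyl group there could test this, since neither nitro nor fluorine substitution gives a readable value.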